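The source may report more compounds than this note shows. Statements on the series, on what has been measured and on what is new or still open speak of the compounds shown alone.

Compound 1, `COc1ccc(-c2ccn(CCC(C)C)c(=O)c2C#N)cc1`, and compound 2, `COc1ccc(-c2ccn(CCC(C)C)c(=O)c2C#N)cc1Cl`, share one core and differ by a single chlorine atom. In a functional assay on CHO cells for positive allosteric modulation of metabotropic glutamate receptor 2 (Homo sapiens), read by scintillation counting and GTPgammaS binding, with a stated time of 30 min (a higher number here means that more compound is needed for the effect, a lower number that less compound is needed), compound 1 gives 1150 nM, and compound 2 gives 363 nM. The change between them is chloro in place of hydrogen on an aromatic carbon, and the step it made is a 3.2-fold lower number from compound 1 to compound 2 (0.50 log units; beyond the scatter).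

Compound 3, `CCCCn1ccc(-c2ccc(Oc3ccnc(C)c3)cc2)c(C#N)c1=O`, rests on a different core; the difference between the two cores is not broken down here. In this assay compound 3 gives 398 nM, which lies close to the value of compound 2 and apart from the value of compound 1.

Compound 4, `CCCCn1ccc(-c2ccc(Oc3ccnc(C)c3)cc2Cl)c(C#N)c1=O`, is not yet measured. It is made from compound 3 by chloro in place of hydrogen on an aromatic carbon. Among the compounds with values here, this is the same kind of change as the one from compound 1 to compound 2, not the same change: in compound 2 the chlorine sits ortho to a methoxy group and meta to a large group, whereas in compound 4 it sits ortho to a large group and meta to a (2-methylpyridin-4-yl)oxy group.

Within the data shown here, the only guide for compound 4 is the single earlier step. For compound 4 in this assay a step of a 2.5-fold lower number from compound 3 to compound 4 (0.40 log units; beyond the scatter) is expected, a little smaller than the earlier one because of a 3.2-fold lower number from compound 1 to compound 2 (0.50 log units; beyond the scatter) on a different core. For compound 4 the estimate in this assay is therefore 160 nM, with a range from 60 nM to 450 nM.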

Compound 4, half-maximal effective concentration: 933 nM
For compound 4 the middle estimate is 5.8-fold (0.77 log units) below the measured one; the measured number lies above the stated range.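

In this assay, the same swap of hydrogen for chloro that helped on the first core does the opposite on this one, giving a 2.3-fold higher number from compound 3 to compound 4 (0.37 log units; beyond the scatter), so more compound is needed after the change, not less. These two pairs cannot say why, since the cores differ in more than one place and the chlorine of compound 4 sits ortho to a large group and meta to a (2-methylpyridin-4-yl)oxy group, whereas that of compound 2 sits ortho to a methoxy group and meta to a large group; the place of the chlorine and the rest of the core cannot be told apart here. What the comparison does show is that, in this series, a gain from this change on one core is no safe guide to its result on another, as the two steps run in opposite directions and their gap is larger than repeated measurements would explain: the same change on two cores in this assay, a 3.2-fold lower number (0.50 log units; beyond the scatter) from compound 1 to compound 2 and a 2.3-fold higher number (0.37 log units; beyond the scatter) from compound 3 to compound 4, 7.4-fold (0.87 log units) apart, beyond the scatter of two such steps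

The compounds shown leave open whether a chlorine ortho to a large group would also raise the number on the core of compound 1, which would point to the place of the atom and not to the core. They also leave open whether a fluorine or a bromine in the same place on compound 3 would move the number in the same direction as chlorine does.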